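The source may report more compounds than this note shows. Statements on the series, on what has been measured and on what is new or still open speak of the compounds shown alone.

In a functional assay on HCT-116 cells (Homo sapiens) for cytotoxicity, read by MTT assay, with a stated time of 72 h (a lower number here means a stronger inhibitor, a higher number a weaker inhibitor), compound 1 (`Cc1ccc(/C=C/C=C2\CCC=CC2=O)cc1`) gives 7200 nM and compound 2 (`O=C1C=CCC/C1=C\C=C\c1ccc(Br)cc1`) gives 5200 nM on the same read-out. Going by the values given here, compound 2 therefore stands level with compound 1, with a 1.4-fold lower number from compound 1 to compound 2 (0.14 log units; within the scatter) as the only measured step. Compound 3 (`CC(=O)Oc1ccc(/C=C/C=C2\CCC=CC2=O)cc1`) keeps the shared core and carries acetoxy in place of bromo on an aromatic carbon, para to a large group (acetoxy in place of bromo on an aromatic carbon). Among the compounds with values here, only the step from methyl to bromo, made at that same carbon, bears on this change, and it stayed within the scatter. Within the data shown here, no measured compound carries acetoxy, so the data point in no direction, and no step beyond the scatter is expected in this assay here. The expected change is a 1.1-fold higher number from compound 2 to compound 3 (0.02 log units; within the scatter) and no more than that. Compound 3 is estimated at 5500 nM (expected range 2000 nM to 15000 nM).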

Compound 3, half-maximal inhibitory concentration: 4600 nM
Beside the measured number, compound 3's estimate is 1.2-fold (0.08 log units) above it; the range from low to high includes it.
By their numbers in this assay, from the lowest: compounds 3, 2 and 1 (each within the scatter of the next).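

Acetoxy, with 4 heavy atoms and 2 hydrogen-bond acceptors, replaces the single bromine atom at this aromatic carbon, yet this assay gives a 1.1-fold lower number from compound 2 to compound 3 (0.05 log units; within the scatter) and so places the two compounds level. The comparison with methyl reads the same, with a 1.6-fold lower number from compound 1 to compound 3 (0.19 log units; within the scatter) at that carbon, so methyl, bromo and acetoxy all stand within the scatter of one another, and a larger group carrying hydrogen-bond acceptors brings no step beyond it. No measurement at hand accounts for this level result.

As far as these compounds go, what an amine, a carboxylic acid or a longer chain would give at this carbon remains open, and so does whether any group there can produce a step beyond the scatter. The compounds shown also leave open how changes elsewhere on the shared core would read in this assay.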